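Compound 3 to compound 4: bromo for methoxy

This account rests on a few compounds, and the source may have more. Where it says the series, first, only, none or still open, it means among the compounds named here.

In a functional assay on MCF7 cells (Homo sapiens) for antiproliferative activity, read by MTT assay (on this read-out lower numbers stand for stronger inhibition and higher numbers for weaker inhibition), compound 3 (`COc1ccc(-c2ccnc(Nc3cccc(OC)c3)n2)cc1`) gives 3450 nM and is the lowest of the three measured numbers. Compound 1 (`Cc1cccc(Nc2nccc(-c3ccc(Br)cc3)n2)c1`) gives 210000 nM and compound 2 (`COc1cccc(Nc2nccc(-c3ccc(F)cc3)n2)c1`) gives 412000 nM in the same read-out. Compound 4 (`COc1cccc(Nc2nccc(-c3ccc(Br)cc3)n2)c1`) has bromo in place of methoxy on an aromatic carbon, para to a large group (bromo in place of methoxy on an aromatic carbon). The nearest measured precedent at this place is methoxy in place of fluoro, with a 120-fold lower number from compound 2 to compound 3 (2.08 log units; beyond the scatter) as a large step beyond the scatter. Compound 1 also carries bromo at this place and stands at 210000 nM in this assay as well. Losing the methoxy is therefore expected to reverse most of that step, towards a higher number. The expected change is a 58-fold higher number from compound 3 to compound 4 (1.76 log units; beyond the scatter) as estimated here. Compound 4 is estimated at 200000 nM with an expected range from 70000 nM to 550000 nM in this series.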

Compound 4, half-maximal inhibitory concentration: 278000 nM
Beside the measured number, compound 4's estimate is 1.4-fold (0.14 log units) below it; the measured number falls inside the stated range.
By their numbers in this assay, from the lowest: compound 3; then compounds 1, 4 and 2 (each within the scatter of the next).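

In this assay, methoxy at this place stands apart from bromo, with an 81-fold higher number from compound 3 to compound 4 (1.91 log units; beyond the scatter), while bromo and fluoro remain unseparated, with a 1.5-fold lower number from compound 2 to compound 4 (0.17 log units; within the scatter). With bromo at this place, methoxy in place of methyl on the other substituted aromatic carbon also gives no separation, with a 1.3-fold higher number from compound 1 to compound 4 (0.12 log units; within the scatter). Among the compounds shown, the low number therefore goes only with compound 3, the one compound carrying methoxy at this place. No evidence on the origin of this step is available. As far as these compounds go, whether an amine, a hydroxyl or an ethoxy group at this place would keep the low number remains open.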